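The compounds below may be only part of what the source reports. "The series", "measured", "known", "first", "only" and "open" are said of these compounds alone.

Measured compounds:
compound 1, `Nc1ccccc1NC(=O)c1ccc(CSC(=S)N2CCN(C3CCCCC3)CC2)cc1`, 76.1%
compound 2, `CC1CCCCN1C(=S)SCc1ccc(C(=O)Nc2ccccc2N)cc1`, 76.3%
compound 3, `Nc1ccccc1NC(=O)c1ccc(CSC(=S)N2CCc3ccc([N+](=O)[O-])cc32)cc1`, 62.1%

Of the compounds shown here, three have been tested in a functional assay on HeLa cells (Homo sapiens) for antiproliferative activity, read by CCK-8 assay, with a stated time of 72 h, tested at 8 uM; on this read-out higher numbers stand for a stronger effect at the one concentration tested and lower numbers for a weaker effect. Compound 1 gives 76.1%, and compound 2 gives 76.3%; the two numbers lie within the scatter of each other, so nothing separates them. Compound 3 gives 62.1%, a number that stands beyond the scatter below compound 1. On the numbers shown, compound 1 is thus the second highest of the three, with compound 2 at its side and compound 3 clearly lower.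

Compound 4, `Nc1ccccc1NC(=O)c1ccc(CSC(=S)N2CCN(c3ccncc3)CC2)cc1`, has not yet been measured in this assay . It differs from compound 1 in one place: pyridin-4-yl in place of cyclohexyl on an amine nitrogen in a ring. For the measured compounds named here, no pair of measured compounds differs by a single such change, so no measured step tells how this assay responds to it. The three numbers in hand show that the group on the thiocarbamate nitrogen can move the result beyond the scatter, as compound 3 does relative to compound 1, but the direction for a pyridin-4-yl group cannot be read from them.

The step from compound 1 to compound 4 is therefore expected to be modest, a number 10.1 percentage points lower from compound 1 to compound 4 (beyond the scatter), most likely downward but not clearly beyond the scatter. Compound 4 is estimated to give 66% in this assay , within a range from 45% to 84%.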

Compound 4, a percentage reported as inhibition, at one concentration (the size of the read-out at that concentration, not a potency): 77.4%
Estimate against measurement, compound 4: 11.4 percentage points below, within the range that was stated.
By their numbers in this assay, from the lowest: compound 3; then compounds 1, 2 and 4 (each within the scatter of the next).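

In this assay, for the compounds shown here, the change from cyclohexyl to pyridin-4-yl on an amine nitrogen in a ring gives a number 1.3 percentage points higher from compound 1 to compound 4 (within the scatter) and is the first single change at this position that can be read. At the one concentration tested, the read-out therefore does not separate a six-membered non-aromatic ring of carbon only from a six-membered aromatic ring with 1 hetero atom at this place, even though the entering group carries 1 hydrogen-bond acceptor and the leaving group carries none. Nothing at hand explains why the change leaves the result within the scatter.

The compounds shown do not tell how a carboxylic acid, or a longer chain ending in an amine, would fare on this same nitrogen, so this one step cannot be extended to groups of other kinds. The read-out also gives the size of the effect at a single concentration rather than a potency, which leaves open whether compound 1 and compound 4 would still match across a range of concentrations.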